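Bis-sulfonamide carboxylic acids against liver carboxylesterase 1

The source may hold more compounds than are shown below. What is called first, only, known or untested is meant among the compounds shown, and "the series" means these compounds.

Measured so far:
compound 1 `O=C(O)c1ccc(S(=O)(=O)Nc2ccc(NS(=O)(=O)c3ccc(F)cc3)cc2)cc1` — > 100000 nM
compound 2 `O=S(=O)(Nc1ccc(NS(=O)(=O)c2cc(F)cc(F)c2)cc1)c1cc(F)cc(F)c1` — > 100000 nM

In an assay for inhibition of liver carboxylesterase 1 (Homo sapiens), read by spectrophotometry (on this read-out lower numbers stand for stronger inhibition and higher numbers for weaker inhibition), compound 1 gives > 100000 nM, which is a limit of the assay rather than a number. Compound 2 likewise gives only a limit, > 100000 nM. Both values sit at the limit of > 100000 nM in this assay, at which 2 of the 2 values shown sit, so compound 1 cannot be placed relative to anything else.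

Compound 3 `Cc1ccc(C(=O)O)cc1S(=O)(=O)Nc1ccc(NS(=O)(=O)c2ccc(F)cc2)cc1` carries 5-carboxy-2-methylphenyl in place of 4-carboxyphenyl on a sulfonyl sulfur, that is 5-carboxy-2-methylphenyl in place of 4-carboxyphenyl on a sulfonyl sulfur. Within the data shown here, no measured step in this assay bears on this change, and the expected step from compound 1 to compound 3 is a step that the limit leaves unreadable from compound 1 to compound 3, none beyond the scatter. Compound 3 is thus estimated at 150000 nM (range 30000 nM to 1000000 nM), most likely reported again only as a limit.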

Compound 3, inhibition constant: > 100000 nM
Compound 3: no number, only a limit; the forecaster's own chance of this, stated with the estimate: 85%; the middle value does not contradict the limit.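

Compound 1 and compound 3 both stand only as limits of the assay, so no step between them can be read: the limit of > 100000 nM in this assay, at which 3 of the 3 values shown sit.

The compounds shown leave open whether any change to the shared core gives an actual number in this assay.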